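A few compounds are considered here, and "the series" means these few. Any claim that something is new, unique, unknown or untested is made for them only; others in the source may bear on it.

In an ADME assay on isolated protein for inhibition of protein deacetylase HDAC6 (Homo sapiens), read by fluorescence, with stated times of 3 h and 60 min (a higher number here means a weaker inhibitor, a lower number a stronger inhibitor), compound 1 `N[C@@H](CCCCCC(=O)c1ccon1)c1ncc(-c2ccccc2F)[nH]1` returns only a limit, > 45000 nM. Compound 2 `CN1CCC(C(=O)N[C@@H](CCCCCC(=O)c2nccs2)c2ncc(-c3ccc(F)cc3)[nH]2)CC1` likewise returns only a limit in this assay, > 45000 nM. Within the data shown here, every value so far thus sits at the limit of > 45000 nM in this assay, at which 2 of the 2 values shown sit, and compound 2 stands at that limit rather than at a number. Compound 3 `Cc1coc(C(=O)CCCCC[C@H](NC(=O)C2CCN(C)CC2)c2ncc(-c3ccc(F)cc3)[nH]2)n1` carries 4-methyl-1,3-oxazol-2-yl in place of 1,3-thiazol-2-yl on a carbonyl carbon. Among the measured compounds shown here, no measured step is available to draw on, so the expected step of a number no higher from compound 2 to compound 3 (the limit leaves the size open) is taken as none beyond the scatter. Compound 3 is therefore expected at about 45000 nM, within 20000 nM to 100000 nM, most probably reported again only as a limit.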

Compound 3, half-maximal inhibitory concentration: > 15000 nM
Compound 3 was reported as a limit; the forecaster's own chance of this, stated with the estimate: 80%; the middle value is on the limit's open side.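

In this assay compound 2 gives only a limit, > 45000 nM. Among these compounds, compound 3 also gives only a limit, > 15000 nM, so no step between these two compounds can be read. From the compounds shown here alone, whether 4-methyl-1,3-oxazol-2-yl in place of 1,3-thiazol-2-yl changes inhibition at all stays open.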